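A few compounds are considered here, and "the series" means these few. Any claim that something is new, unique, unknown or untested is made for them only; others in the source may bear on it.

Compound 1 `O=C(Nc1cc(C(F)(F)F)cc(C(F)(F)F)c1)c1cc(F)ccc1O` gives 2500 nM in an ADME assay on cells (Macrophage, Mus musculus) for cytotoxicity, read by resazurin assay, with a stated time of 3 days; on this read-out higher numbers stand for weaker inhibition and lower numbers for stronger inhibition.
Compound 2 `O=C(Nc1cc(C(F)(F)F)cc(C(F)(F)F)c1)c1cc(Br)ccc1O` gives 4900 nM in this assay.
Compound 3 `O=C(Nc1ccc(F)cc1C(F)(F)F)c1cc(Cl)ccc1O` gives 13000 nM in this assay.

Compound 4 `O=C(Nc1ccc(Br)cc1C(F)(F)F)c1cc(Cl)ccc1O` has not yet been measured. It arises from compound 3 by one change: bromo in place of fluoro on an aromatic carbon. The same kind of change is seen between two measured compounds, from compound 1 to compound 2: bromo in place of fluoro on an aromatic carbon. There the step was a 2.0-fold higher number from compound 1 to compound 2 (0.29 log units; within the scatter). The surroundings of the change are not identical, though: in compound 1 the exchanged atom is meta to a large group and para to a hydroxy group, whereas in compound 3 it is meta to a trifluoromethyl group and para to a large group. How the core of compound 1 and the core of compound 3 differ is not broken down here. Compound 3 gives the highest number of the three measured compounds.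

Because the earlier step of a 2.0-fold higher number from compound 1 to compound 2 (0.29 log units; within the scatter) stayed within the scatter, a step of similar size is expected here, a 1.4-fold higher number from compound 3 to compound 4 (0.14 log units; within the scatter), so compound 4 is estimated at 18000 nM, most likely between 7000 nM and 45000 nM in this assay.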

Compound 4, half-maximal inhibitory concentration: 11000 nM
Compound 4: middle estimate off by 1.6-fold (0.21 log units), on the high side, and the stated range covers the measured number.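

Putting bromo in place of fluoro gives a 1.2-fold lower number from compound 3 to compound 4 (0.07 log units; within the scatter) in this assay, a step too small to tell apart from repeat measurement. Set beside the earlier case, the two steps do not differ by more than such steps usually do: the same change on two cores in this assay, a 2.0-fold higher number (0.29 log units; within the scatter) from compound 1 to compound 2 and a 1.2-fold lower number (0.07 log units; within the scatter) from compound 3 to compound 4, 2.3-fold (0.36 log units) apart, within the scatter of two such steps. So the exchange behaves alike on the core of compound 1 and the core of compound 3 as far as these two pairs can tell, but neither step shows a real effect of the exchange on its own core, and two pairs say nothing about other cores or other places on the ring.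

The compounds shown leave open whether a different group at this place, such as an amine, a nitrile or a carboxylic acid, would give a step beyond the scatter in this assay. Also open, as far as these compounds go, is what a methoxy group in place of the hydroxy group would do to the number on either core.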